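This account rests on a few compounds, and the source may have more. Where it says the series, first, only, none or still open, it means among the compounds named here.

Measured compounds:
compound 1 `COc1ccc(-c2cc(C(=O)/C=C/c3ccccc3)nc3cc(-c4ccccc4)nn23)cc1OC` — 64100 nM
compound 2 `COc1cc(-c2cc(C(=O)/C=C/c3ccccc3)nc3cc(-c4ccccc4)nn23)cc(OC)c1OC` — 44800 nM
compound 3 `COc1ccc(C(=O)/C=C/c2cc(-c3ccc(OC)c(OC)c3)n3nc(-c4ccccc4)cc3n2)cc1OC` — 32500 nM

In an ADME assay on HEK293 cells (Homo sapiens) for antiproliferative activity, read by MTT assay, with a stated time of 24 h (on this read-out lower numbers stand for stronger inhibition and higher numbers for weaker inhibition), compound 2 gives 44800 nM, the second highest of the three numbers; its neighbours lie close on either side, compound 3 with 32500 nM and compound 1 with 64100 nM, and both gaps are within the scatter. Compound 4 `COc1cc(-c2cc(C(=O)/C=C/c3ccc(C)cc3)nc3cc(-c4ccccc4)nn23)cc(OC)c1OC` has not yet been measured in this assay. It differs from compound 2 in one place: methyl in place of hydrogen on an aromatic carbon.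

Within the data shown here, no measured step bears directly on this change. Among the measured compounds shown here, the only step available, a 1.4-fold lower number from compound 1 to compound 2 (0.16 log units; within the scatter), adds a methoxy group on a different ring of the shared core and stays within the scatter. The pair compound 2 and compound 3, which moves the substituent pattern between the two aryl positions, shows two values within the scatter of each other. All three numbers thus sit in a narrow band, and nothing in them suggests that a single methyl on the phenyl ring would move the read-out beyond that band.

Compound 4 is therefore expected to give a number close to compound 2, with a step of a 1.1-fold lower number from compound 2 to compound 4 (0.05 log units; within the scatter) in this assay, and its estimated value is 40000 nM, with a range from 15000 nM to 100000 nM.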

Compound 4, half-maximal inhibitory concentration: 56100 nM
Estimate against measurement, compound 4: 1.4-fold (0.15 log units) below; low and high end bracket the measured number.
By their numbers in this assay, from the lowest: compounds 3, 2, 4 and 1 (each within the scatter of the next).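

Compound 4 alone among the compounds shown carries a substituent on this phenyl ring, with 2-(4-methylphenyl)ethenyl in the place of the 2-phenylethenyl group of compound 2. In this assay, among these compounds, methyl in place of hydrogen, para to a large group, gives a 1.3-fold higher number from compound 2 to compound 4 (0.10 log units; within the scatter), so the earlier step, which concerned a methoxy group on a different ring, is now joined by a first reading at this position, and a methyl here leaves the read-out inside the scatter. No independent measurement is available to explain this result.

The compounds shown leave open whether this position is insensitive in general or only to a group as small as methyl: an amine, a carboxylic acid or a longer chain such as butyl at the same place might or might not separate from compound 2 in this assay. They also leave open whether methyl would behave in the same way on the phenyl ring of the 2-phenylethenyl group when the other aryl ring carries the substitution pattern of compound 1.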